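This account rests on a few compounds, and the source may have more. Where it says the series, first, only, none or still open, it means among the compounds named here.

Measured compounds:
Compound 1, `CN(C)c1ccc(NC(=O)Nc2cccc(CNc3nccnc3Cl)c2)cc1`
Compound 2, `Cc1ccc(NC(=O)Nc2cccc(CNc3nccnc3Cl)c2)c(C)c1`
Compound 3, `O=C(Nc1cccc(CNc2nccnc2Cl)c1)Nc1ccccc1F`

In a functional assay on HepG2 cells (Homo sapiens) for antiproliferative activity, read by MTT assay, with a stated time of 48 h (on this read-out lower numbers stand for stronger inhibition and higher numbers for weaker inhibition), compound 1 gives > 40000 nM, which is a limit of the assay rather than a number. In this assay compound 2 gives 9290 nM. In this assay compound 3 gives 10500 nM. Among the two numbers, compound 2 gives the lowest, though the gap to compound 3 is a 1.1-fold higher number from compound 2 to compound 3 (0.05 log units; within the scatter). The two measured steps that cross the limit, an at least 4.3-fold lower number from compound 1 to compound 2 (0.63 log units; beyond the scatter) and an at least 3.8-fold lower number from compound 1 to compound 3 (0.58 log units; beyond the scatter), concern the aryl group on the amide-type nitrogen; the limit itself is the limit of > 40000 nM in this assay, at which 1 of the 3 values shown sits.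

Compound 4, `Cc1ccc(NC(=O)Nc2cccc(CNc3nccnc3Cl)c2)cc1`, is not yet measured. It differs from compound 2 by hydrogen in place of methyl on an aromatic carbon. Going by the values given here, no measured step removes a methyl from this aryl group, so the expectation rests on the small gap between compound 2 and compound 3, where two different aryl groups gave nearly the same number. The step is therefore expected to be a 1.3-fold higher number from compound 2 to compound 4 (0.11 log units; within the scatter), within the scatter. Compound 4 is estimated to give 12000 nM, between 5000 nM and 30000 nM.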

Compound 4, half-maximal inhibitory concentration: 11500 nM
Beside the measured number, compound 4's estimate is 1.0-fold (0.02 log units) above it, within the range that was stated.
By their numbers in this assay, from the lowest: compounds 2, 3 and 4 (each within the scatter of the next). At a limit, above all of these: compound 1.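

In this assay, going from 2,4-dimethylphenyl to 4-methylphenyl gives a 1.2-fold higher number from compound 2 to compound 4 (0.09 log units; within the scatter) so the methyl ortho to a large group can be replaced by hydrogen with no change that stands out from the scatter. The 4-methylphenyl group also reads level with 2-fluorophenyl, with a 1.1-fold higher number from compound 3 to compound 4 (0.04 log units; within the scatter) so these three aryl groups on the amide-type nitrogen cannot be told apart, and only the 4-(dimethylamino)phenyl group of compound 1 goes against that pattern. The step of an at least 3.4-fold lower number from compound 1 to compound 4 (0.54 log units; beyond the scatter) gives only a bound and not a size, since the value of compound 1 is a limit: the limit of > 40000 nM in this assay, at which 1 of the 4 values shown sits.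

The compounds shown leave open how a plain phenyl group, with neither methyl, would read. They also leave open whether a methoxy group, a smaller amine or a carboxylic acid in place of the remaining methyl would read like the methyl or like the dimethylamino group.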